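Methyl for hydrogen on the chain carbon: an expectation

A few compounds are considered here, and "the series" means these few. Any claim that something is new, unique, unknown or untested is made for them only; others in the source may bear on it.

Compound 1 `C/N=C(\NC#N)NCCSCn1nc(C)ccc1=O` shows in a functional assay on the whole organism (stomach) for inhibition, with Rattus norvegicus as the target, with a stated time of 4 h (on this read-out lower numbers stand for an effect already at smaller amounts and higher numbers for an effect only at larger amounts of compound), a limit of > 100 mg/kg, not a number.
Compound 2 `CC/N=C(\NC#N)NCCSCn1nc(C)ccc1=O` shows in this assay a limit of > 100 mg/kg.
Compound 3 `C/N=C(\NC#N)NCCSCn1nc(-c2ccccc2)ccc1=O` shows in this assay a limit of < 30.5 mg/kg.

Compound 3 thus sits at the limit of < 30.5 mg/kg in this assay, at which 1 of the 3 values shown sits, while the two other compounds sit at the limit of > 100 mg/kg in this assay, at which 2 of the 3 values shown sit. Compound 4 `CC/N=C(\NC#N)NCCSCn1nc(-c2ccccc2)ccc1=O` differs from compound 3 by methyl in place of hydrogen on a saturated chain carbon bound to a double-bonded nitrogen. The same change was measured once before, as a step that the two limits leave unreadable from compound 1 to compound 2, and so tells nothing about its size. Going by the values given here, the only readable step is an at least 3.2-fold lower number from compound 1 to compound 3 (0.51 log units; beyond the scatter), which concerns a different part of the molecule. Compound 4 is therefore expected to remain close to compound 3, with a step that the limit leaves unreadable from compound 3 to compound 4 being no change beyond the scatter, and compound 4 is estimated at 15 mg/kg, within 4 mg/kg to 60 mg/kg.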

Compound 4, dose for half-maximal effect: < 100 mg/kg
Compound 4 was reported as a limit; the forecaster's own chance of this, stated with the estimate: 45%; the middle value is on the limit's open side.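

In this assay compound 4 gives < 100 mg/kg, a limit and not a number. The step to it from compound 3 cannot be read, so methyl in place of hydrogen on the saturated chain carbon remains unsized on both cores. What is new is a second pair for phenyl in place of methyl on the aromatic carbon, which shows a number no higher from compound 2 to compound 4 (the limit leaves the size open), and its direction does not go against the first: the same change on two cores in this assay, an at least 3.2-fold lower number (0.51 log units; beyond the scatter) from compound 1 to compound 3 and a number no higher (the limit leaves the size open) from compound 2 to compound 4; the limit leaves it open whether they differ

The compounds shown leave open whether the methyl change moves the number at all on the phenyl core, and how a longer chain such as propyl would read there.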